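Chloro for Methoxy, Repeated on a Pyridine Ring

This account rests on a few compounds, and the source may have more. Where it says the series, first, only, none or still open, it means among the compounds named here.

Compound 1, `COc1ccc(NC(=O)c2c(O)c3cccnc3n(-c3ccccc3)c2=O)cc1`, gives -1.9% in a functional assay on the whole organism for inhibition, with Rattus norvegicus as the target, read by cytopathic effect and paw edema, at a dose of 100 mg/kg by the oral route; a higher number here means more inhibition at the dose given (going by the name of the read-out), a lower number less inhibition.
Compound 2, `O=C(Nc1ccc(Cl)cc1)c1c(O)c2cccnc2n(-c2ccccc2)c1=O`, gives 2.5% in this assay.
Compound 3, `COc1ccc(NC(=O)c2c(O)c3cccnc3n(-c3ccccc3)c2=O)cn1`, gives -10.2% in this assay.

Of the compounds shown here, three sharing one core have been measured. Compound 1 and compound 2 differ by chloro in place of methoxy on an aromatic carbon, and that change made a number 4.4 percentage points higher from compound 1 to compound 2 (within the scatter). Compound 1 and compound 3 differ by 6-methoxypyridin-3-yl in place of 4-methoxyphenyl on an amide-type nitrogen, giving a number 8.3 percentage points lower from compound 1 to compound 3 (within the scatter). Between compound 2 and compound 3 the step is a number 12.7 percentage points lower from compound 2 to compound 3 (beyond the scatter), the only gap here that stands out from the noise of repeated measurement.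

Compound 4, `O=C(Nc1ccc(Cl)nc1)c1c(O)c2cccnc2n(-c2ccccc2)c1=O`, has not yet been measured. It differs from compound 3 by chloro in place of methoxy on an aromatic carbon. Going by the values given here, this is the same kind of change as the one from compound 1 to compound 2, but not the same: in compound 1 the change sits on a six-membered aromatic ring of carbon only, whereas in compound 3 it sits on a six-membered aromatic ring with 1 nitrogen, next to the ring nitrogen.

Because the earlier step, a number 4.4 percentage points higher from compound 1 to compound 2 (within the scatter), stayed within the scatter, compound 4 is expected to move from compound 3 by a similarly small amount, estimated as a number 4.2 percentage points higher from compound 3 to compound 4 (within the scatter). Compound 4 is therefore estimated at -6% in this assay, with a plausible range from -20% to 8%.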

Compound 4, a percentage reported as inhibition, in the whole organism at one dose (the size of the read-out at that dose, not a potency): -4%
Compound 4: the middle estimate sits 2 percentage points below what was measured, and the stated range covers the measured number.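

On the six-membered aromatic ring with 1 nitrogen, chloro in place of methoxy gives a number 6.2 percentage points higher from compound 3 to compound 4 (within the scatter) in this assay, and this agrees with the step seen on the all-carbon ring: the same change on two cores in this assay, a number 4.4 percentage points higher (within the scatter) from compound 1 to compound 2 and a number 6.2 percentage points higher (within the scatter) from compound 3 to compound 4, 1.8 percentage points apart, within the scatter of two such steps. The two other new steps, a number 6.5 percentage points lower from compound 2 to compound 4 (within the scatter) and a number 2.1 percentage points lower from compound 1 to compound 4 (within the scatter), are also small enough that neither pair can be told apart in this measurement. Across these two pairs, then, the change carries from one core to the other as a step too small to stand out, but that does not show a real shared effect, since both steps lie within the usual scatter and come from a single dose in a single assay.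

The compounds shown leave open whether a group other than methoxy or chloro at this spot, such as an amine or a carboxylic acid, would give a step large enough to stand clear of the scatter. They also leave open whether chloro in place of methoxy would behave the same way if the phenyl group on the ring nitrogen of the shared core gave way to a longer chain.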